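The source may hold more compounds than are shown below. What is called first, only, known or untested is meant among the compounds shown, and "the series" means these compounds.

Two members of one small series have been measured in a functional assay on K562 cells (Homo sapiens) for inhibition, read by fluorescence, with a stated time of 72 h; a higher number here means a weaker inhibitor of growth, a lower number a stronger inhibitor of growth. Compound 1 `Cc1nccc2nn(-c3ccccc3)cc12` is the simplest of them. In this assay compound 1 gives > 100000 nM, which is a limit of the assay rather than a number. Compound 2 `CC(C)c1nc(-c2ccccc2)cc2nn(-c3ccccc3)cc12` carries an isopropyl group and a second phenyl group, and in this assay compound 2 gives 36800 nM. Among the values shown, that is the only one that is a number; the other value shown is a limit, as noted in the limit of > 100000 nM in this assay, at which 1 of the 2 values shown sits.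

The next compound is compound 3 `CC(C)c1nccc2nn(-c3ccccc3)cc12`. It differs from compound 2 in one place: hydrogen in place of phenyl on an aromatic carbon. The change sits on an aromatic carbon of a six-membered aromatic ring with 1 nitrogen, part of a fused or bridged system of two rings. Among the compounds with values here, no measured pair of compounds shows this change on its own, so its size here is unknown. Because compound 1, which also lacks that phenyl group, sits at > 100000 nM, the expectation is that the removal weakens growth inhibition, with a step from compound 2 to compound 3 of about a 3.3-fold higher number from compound 2 to compound 3 (0.51 log units; beyond the scatter) expected. For compound 3 an estimated value of 120000 nM is expected, in a range from 40000 nM to 400000 nM, and a result reported only as a limit would not be surprising.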

Compound 3, concentration for 50% growth inhibition: > 100000 nM
Compound 3 was reported as a limit (the forecaster's own chance of this, stated with the estimate: 60%); the middle value lies beyond the limit too.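

Taking the phenyl group off the aromatic carbon next to the ring nitrogen gives the first comparison in this series that changes one place only, and in this assay it produces an at least 2.7-fold higher number from compound 2 to compound 3 (0.43 log units; beyond the scatter). Within the data shown here, this ties the only numerical value to the presence of that phenyl group, and the step is only a lower bound, so the true loss of growth inhibition could be larger. The step for isopropyl in place of methyl, from compound 1 to compound 3, cannot be read because both compounds are reported only as limits: the limit of > 100000 nM in this assay, at which 2 of the 3 values shown sit.

On these data alone, it remains open whether this carbon needs an aromatic ring at all, or whether a chlorine atom, an amine or a benzyl group there would also give a measurable value. Also open, as far as these compounds go, is what the isopropyl group contributes when the phenyl group is present, a question that a compound with both methyl and phenyl on the core of compound 1 could answer in comparison with compound 2.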